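Swapping the ring-nitrogen ethyl for a methoxycarbonyl

A few compounds are considered here, and "the series" means these few. Any claim that something is new, unique, unknown or untested is made for them only; others in the source may bear on it.

Of the compounds shown here, two share a hexylcarbamoyl-bearing core and have been measured in an assay on HEK293 cells for inhibition of acid ceramidase (Rattus norvegicus), read by LC-MS, with a stated time of 30 min; on this read-out lower numbers stand for stronger inhibition and higher numbers for weaker inhibition. Compound 1 `CCCCCCNC(=O)n1cc(C(F)(F)F)c(=O)[nH]c1=O` gives 12 nM in this assay. Compound 2 `CCCCCCNC(=O)n1cc(F)c(=O)n(CC)c1=O` gives 18 nM in this assay, the higher of the two numbers, though its gap to compound 1 stays within the scatter. Compound 3 `CCCCCCNC(=O)n1cc(F)c(=O)n(C(=O)OC)c1=O` differs from compound 2 by methoxycarbonyl in place of ethyl on an aromatic nitrogen. With no comparable change measured, the step is expected to be modest and towards a higher number, with no direction certain beyond the scatter, expected as a 1.4-fold higher number from compound 2 to compound 3 (0.14 log units; within the scatter). Compound 3 is estimated at 25 nM, between 6 nM and 100 nM.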

Compound 3, half-maximal inhibitory concentration: 7 nM
The estimate for compound 3 lay 3.6-fold (0.55 log units) above the measured number; low and high end bracket the measured number.
By their numbers in this assay, from the lowest: compounds 3, 1 and 2 (each within the scatter of the next, the first and the last beyond it).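

In this assay the aromatic nitrogen accepts a larger group than ethyl without loss: methoxycarbonyl in its place gives a 2.6-fold lower number from compound 2 to compound 3 (0.41 log units; beyond the scatter) and so improves on compound 2 by a modest step. Going by these compounds alone, this is the first single change read at this position, and it shows that the substituent on this nitrogen can move the number beyond the scatter. No measurement shown here explains the step.

On these data alone, whether the carbonyl or the methoxy part carries the step stays open, as does how an acetyl, an ethoxycarbonyl or a plain methyl would read on this nitrogen.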